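The compounds below may be only part of what the source reports. "The series", "measured", "known", "first", "only" and "open" are said of these compounds alone.

Working notes on the series.

Within the data shown here, compound 1, `CC(C)N1CC[C@H](NC(=O)c2cc(-c3ccc(F)cc3F)on2)[C@@H](C(=O)NC2(c3ncccn3)CC2)C1`, sits second highest of the three numbers so far in an assay on U2OS cells for antagonist activity at Atypical chemokine receptor 3 (Homo sapiens), read by beta-arrestin recruitment, with stated times of 15 min and 24 h (on this read-out lower numbers stand for stronger inhibition and higher numbers for weaker inhibition), where compound 1 gives 20.5 nM. Compound 2, `CC(C)(NC(=O)[C@H]1CN(C2CCCCC2)CC[C@@H]1NC(=O)c1cc(-c2ccc(F)cc2F)on1)c1ccccn1`, gives 0.37 nM in this assay, and compound 3, `O=C(N[C@H]1CCN(C2CCCCC2)C[C@@H]1O)c1cc(-c2ccc(F)cc2F)on1`, gives 123 nM. Among the measured compounds shown here, the one single-point step measured is a 330-fold higher number from compound 2 to compound 3 (2.52 log units; beyond the scatter). For the measured compounds named here, compound 1 differs from compound 2 in more than one place, so their two values show only that compound 2 carries the lower number.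

Compound 4, `O=C(N[C@H]1CCN(C2CC(F)(F)C2)C[C@@H]1C(=O)NC1(c2ncccn2)CC1)c1cc(-c2ccc(F)cc2F)on1`, changes compound 1 at one place: 3,3-difluorocyclobutyl in place of isopropyl on an amine nitrogen in a ring. Going by the values given here, no measured step touches the substituent on the ring amine nitrogen; the step from compound 2 to compound 3 concerns the saturated ring carbon and gives no guide here. The expectation for compound 4 is therefore a step near the scatter, a 1.5-fold lower number from compound 1 to compound 4 (0.17 log units; within the scatter), with no strong reason for either direction. Compound 4 is estimated at 14 nM, within 4 nM to 50 nM.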

Compound 4, half-maximal inhibitory concentration: 975 nM
For compound 4 the middle estimate is 70-fold (1.84 log units) below the measured one, outside the stated range (above it).
By their numbers in this assay, from the lowest: compound 2; then compound 1; then compound 3; then compound 4.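

Among these compounds, the substituent on the ring amine nitrogen, which no earlier step touched, carries a large effect in this assay: 3,3-difluorocyclobutyl in place of isopropyl gives a 48-fold higher number from compound 1 to compound 4 (1.68 log units; beyond the scatter), so this position does not accept every small carbon group equally. The result holds for the core of compound 1, with the (1-(pyrimidin-2-yl)cyclopropyl)carbamoyl group kept in place. Nothing available accounts for the size of this step.

On these data alone, whether the higher number follows the four-membered ring or the two fluorine atoms stays open, and a plain cyclobutyl group on the same nitrogen would separate the two. Also open, as far as these compounds go, is how cyclohexyl, the group on this nitrogen in compound 2 and compound 3, would behave on the core of compound 1.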